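A few compounds are considered here, and "the series" means these few. Any claim that something is new, unique, unknown or untested is made for them only; others in the source may bear on it.

Among the compounds with values here, compound 2 `O=C(Nc1cccc(-n2cc(-c3ccncc3)c(-c3ccc(Cl)c(O)c3)n2)c1)Nc1cc(C(F)(F)F)cc(C(F)(F)F)c1` is the one member of the pair with a number in a functional assay on DU-145 cells (Homo sapiens) for inhibition, read by sulforhodamine B assay, with a stated time of 48 h (a higher number here means that more compound is tolerated, a lower number that less compound is tolerated), where compound 2 gives 17400 nM. Compound 1 `COc1cc(-c2nn(-c3cccc(NC(=O)c4ccc(Cl)c(C(F)(F)F)c4)c3)cc2-c2ccncc2)ccc1Cl` returns only a limit in this assay, namely > 32500 nM. Of the two values shown, one is thus a number and one is a limit (the limit of > 32500 nM in this assay, at which 1 of the 2 values shown sits), so compound 2 stands as the sole placed point of the set. Compound 3 `COc1cc(-c2nn(-c3cccc(NC(=O)Nc4cc(C(F)(F)F)cc(C(F)(F)F)c4)c3)cc2-c2ccncc2)ccc1Cl` has not yet been measured in this assay; against compound 2 it carries methyl in place of hydrogen on an oxygen on an aromatic ring. Within the data shown here, no measured pair shares this change, so no measured step fixes its size. Compound 1, which also carries the methoxy, sits at the limit of > 32500 nM in this assay, at which 1 of the 2 values shown sits, which suggests the change may push towards a higher number. The expected step from compound 2 to compound 3 is a 1.5-fold higher number from compound 2 to compound 3 (0.17 log units; within the scatter), at the edge of the scatter. Compound 3 is therefore estimated at 26000 nM, within 10000 nM to 60000 nM, with a real chance that only a limit is returned.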

Compound 3, concentration lethal to 50% of the cells: 21100 nM
Beside the measured number, compound 3's estimate is 1.2-fold (0.09 log units) above it; the measured number falls inside the stated range.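

In this assay, hydroxy to methoxy on the aromatic ring gives a 1.2-fold higher number from compound 2 to compound 3 (0.08 log units; within the scatter). At this position, the hydrogen on the oxygen can thus be exchanged for methyl without a change beyond the scatter, and the methoxy compound 3 still returns a number rather than a limit. Compound 1 remains the only compound with a limit, which is not a number: the limit of > 32500 nM in this assay, at which 1 of the 3 values shown sits.

Within the data shown here, compound 1 differs from compound 3 in more than one place, so no step between them can be read, and what separates their results stays open. Also open, on these data alone, is whether an ethyl group or a longer chain on this oxygen, or an amine in place of the hydroxy, would keep the value in this assay within the scatter.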